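The compounds below may be only part of what the source reports. "The series", "measured", "known", "first", "only" and "open" are said of these compounds alone.

Compound 1 `Cc1cc(C)cc(S(=O)(=O)c2c(C(=O)NCCOc3ccccc3)[nH]c3ccc(Cl)cc23)c1` gives 207000 nM in an ADME assay on CCRF-CEM cells (Homo sapiens) for cytotoxicity, read by cell counting; on this read-out higher numbers stand for lower toxicity in this test and lower numbers for higher toxicity in this test. Compound 2 `Cc1cc(C)cc(S(=O)(=O)c2c(C(=O)NCCOc3ccccc3)[nH]c3ccc(Br)cc23)c1` gives > 500000 nM in this assay, which is a limit of the assay and not a number (the limit of > 500000 nM in this assay, at which 1 of the 3 values shown sits). Compound 3 `Cc1cc(C)cc(S(=O)(=O)c2c(C(=O)NCN3CCCCC3)[nH]c3ccc(Br)cc23)c1` gives 10000 nM in this assay.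

From compound 2 to compound 1 the change is chloro in place of bromo on an aromatic carbon, and it made an at least 2.4-fold lower number from compound 2 to compound 1 (0.38 log units; beyond the scatter). Compound 3 differs from compound 2 in its core, (piperidin-1-yl in place of phenoxymethyl on a saturated chain carbon bound to an amide-type nitrogen), with an at least 50-fold lower number from compound 2 to compound 3 (1.69 log units; beyond the scatter). Compound 4 `Cc1cc(C)cc(S(=O)(=O)c2c(C(=O)NCN3CCCCC3)[nH]c3ccc(Cl)cc23)c1` has not been measured; it differs from compound 3 by chloro in place of bromo on an aromatic carbon, the same change as from compound 2 to compound 1, at the same place.

In this assay a step of a 2.0-fold lower number from compound 3 to compound 4 (0.30 log units; within the scatter) is expected. This expectation rests on an at least 2.4-fold lower number from compound 2 to compound 1 (0.38 log units; beyond the scatter), which starts from a limit and so gives only a lower bound. Compound 4 is therefore estimated at 5000 nM, between 2000 nM and 15000 nM.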

Compound 4, half-maximal cytotoxic concentration: 9900 nM
Estimate against measurement, compound 4: 2.0-fold (0.30 log units) below; low and high end bracket the measured number.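

Chloro in place of bromo on the core of compound 3 gave a 1.0-fold lower number from compound 3 to compound 4 (0.00 log units; within the scatter), so in this assay compound 3 and compound 4 cannot be told apart, and the comparison with the earlier pair stays unsettled: the same change on two cores in this assay, an at least 2.4-fold lower number (0.38 log units; beyond the scatter) from compound 2 to compound 1 and a 1.0-fold lower number (0.00 log units; within the scatter) from compound 3 to compound 4; the limit leaves it open whether they differ. Piperidin-1-yl in place of phenoxymethyl gave a 21-fold lower number from compound 1 to compound 4 (1.32 log units; beyond the scatter), a large step in the same direction as on the bromo pair, but how closely the two sizes match is not shown: the same change on two cores in this assay, an at least 50-fold lower number (1.69 log units; beyond the scatter) from compound 2 to compound 3 and a 21-fold lower number (1.32 log units; beyond the scatter) from compound 1 to compound 4; the limit leaves it open whether they differ. Compound 2, the start of both earlier steps, gives > 500000 nM, which is a limit and not a number: the limit of > 500000 nM in this assay, at which 1 of the 4 values shown sits.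

The compounds shown leave open whether chloro and bromo also match on cores with a longer chain or a morpholine in place of piperidin-1-yl. They also leave open whether fluoro on the same aromatic carbon would fit with chloro and bromo.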